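This account rests on a few compounds, and the source may have more. Where it says the series, first, only, none or still open, it means among the compounds named here.

Measured in an assay on isolated protein for inhibition of proto-oncogene tyrosine-protein kinase receptor Ret (Homo sapiens), read by 33P incorporation, with stated times of 15 min and 40 min; a lower number here means a stronger inhibitor, a higher number a weaker inhibitor:
compound 1, `O=C(Nc1ccc(Nc2ncnc3c2OCCN3)cc1)Nc1ccc(Cl)c(C(F)(F)F)c1`, 177 nM
compound 2, `O=C(Nc1ccc(Cl)cc1)Nc1ccc(Nc2ncnc3c2OCCN3)cc1`, 3070 nM
compound 3, `COc1ccc(NC(=O)Nc2ccc(Nc3ncnc4c3OCCN4)cc2)cc1`, 227 nM

Compound 3 stands second highest of the three numbers; its nearest neighbour is compound 1, which lies within the scatter of it, while compound 2 sits far above it, beyond the scatter. The step to the unmeasured compound 4, `O=C(Nc1ccc(Nc2ncnc3c2OCCN3)cc1)Nc1cc(Cl)cc(Cl)c1`, is 3,5-dichlorophenyl in place of 4-methoxyphenyl on an amide-type nitrogen. Among the compounds with values here, no measured pair makes exactly this change. Within the data shown here, two steps bear on it in part: a 17-fold higher number from compound 1 to compound 2 (1.24 log units; beyond the scatter) shows that taking a substituent off the phenyl of the urea costs a great deal, and a 14-fold lower number from compound 2 to compound 3 (1.13 log units; beyond the scatter) shows that a methoxy on that phenyl recovers almost all of it. Among the measured compounds shown here, compound 4 carries two chlorines on the entering phenyl, and compound 1, the only other compound with more than one substituent there, gives the lowest number seen. The step of a 1.5-fold lower number from compound 3 to compound 4 (0.18 log units; within the scatter) is therefore expected to be small, most likely a slightly lower number, but possibly within the scatter. Compound 4 is estimated at 150 nM in this assay, in the range 40 nM to 600 nM.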

Compound 4, half-maximal inhibitory concentration: 865 nM
Compound 4: middle estimate off by 5.8-fold (0.76 log units), on the low side; measured number above the stated range.
By their numbers in this assay, from the lowest: compounds 1 and 3 (each within the scatter of the next); then compound 4; then compound 2.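

Within the data shown here, the result shows that two substituents on the phenyl at this amide-type nitrogen do not by themselves bring a low number: in this assay, putting 3,5-dichlorophenyl in place of 4-methoxyphenyl gives a 3.8-fold higher number from compound 3 to compound 4 (0.58 log units; beyond the scatter), so the single methoxy group serves better here than the two chlorines. The same group still improves on 4-chlorophenyl, with a 3.5-fold lower number from compound 2 to compound 4 (0.55 log units; beyond the scatter), which places the dichloro compound between the two singly substituted phenyl ureas, and the printed values also separate it from the other disubstituted compound, as compound 1 gives 177 nM and compound 4 gives 865 nM. Nothing measured beyond these numbers accounts for the ordering of these phenyl groups.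

The compounds shown do not separate the number of chlorines from where they stand on the ring, as the names 4-chlorophenyl and 3,5-dichlorophenyl change both at once. They also leave open how this position would respond to an amine or a carboxylic acid on the phenyl, or to a pyridine ring in its place.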